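This account rests on a few compounds, and the source may have more. Where it says the series, first, only, none or still open, it means among the compounds named here.

Compound 1 `N/C(=N\NC(=S)N1CCCCCC1)c1ccccn1` and compound 2 `N/C(=N\NC(=S)N1CCCCC1)c1ccccn1` rest on two related cores; the difference between the two cores is not broken down here. In a functional assay on HeLa cells (Homo sapiens) for cytotoxicity, read by MTT assay, with a stated time of 72 h (a lower number here means a stronger inhibitor, a higher number a weaker inhibitor), compound 1 gives 6000 nM, and compound 2 gives 3800 nM. Compound 3 `Cc1ccnc(/C(N)=N/NC(=S)N2CCCCCC2)c1` arises from compound 1 through one change, (methyl in place of hydrogen on an aromatic carbon); in this assay compound 3 gives 7000 nM, which is a step of a 1.2-fold higher number from compound 1 to compound 3 (0.07 log units; within the scatter). Compound 4 `Cc1ccnc(/C(N)=N/NC(=S)N2CCCCC2)c1` arises from compound 2 through the same change, (methyl in place of hydrogen on an aromatic carbon), made at the same place. Since that change left the number of compound 1 essentially where it was in a 1.2-fold higher number from compound 1 to compound 3 (0.07 log units; within the scatter), a step of similar size is expected here, a 1.2-fold higher number from compound 2 to compound 4 (0.07 log units; within the scatter). On that basis compound 4 is expected to give about 4500 nM in this assay, most likely between 2500 nM and 9000 nM.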

Compound 4, half-maximal inhibitory concentration: 7700 nM
Beside the measured number, compound 4's estimate is 1.7-fold (0.23 log units) below it, and the stated range covers the measured number.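

In this assay, methyl in place of hydrogen opposite the ring nitrogen gives a 2.0-fold higher number from compound 2 to compound 4 (0.31 log units; beyond the scatter), a modest weakening. Set beside the same change on the core of compound 1, the new step does not stand apart: the same change on two cores in this assay, a 1.2-fold higher number (0.07 log units; within the scatter) from compound 1 to compound 3 and a 2.0-fold higher number (0.31 log units; beyond the scatter) from compound 2 to compound 4, 1.7-fold (0.24 log units) apart, within the scatter of two such steps. The change therefore behaves about alike on these two cores, but two pairs cannot show that it would carry to any other core, and they do not explain why one step lies within the scatter and the other just beyond it.

Among the compounds shown, only hydrogen and methyl occupy this place on the ring. As far as these compounds go, what a longer chain, an amine or a carboxylic acid would do there remains open.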